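A few compounds are considered here, and "the series" means these few. Any claim that something is new, unique, unknown or untested is made for them only; others in the source may bear on it.

Measured in a functional assay on HCT-116 cells (Homo sapiens) for cytotoxicity; a higher number here means a weaker inhibitor, a lower number a stronger inhibitor:
- compound 1 `CC(C)C/C=C/C=C/C(=O)NC1=C[C@@](O)(CCC(N)=O)[C@H](O)CC1=O`: 3.15 ug/mL
- compound 2 `CC(C)C/C=C/C=C/C(=O)NC1=CC(O)(CCC(N)=O)C=CC1=O`: 9.99 ug/mL

Compound 2 holds the higher of the two numbers, which makes it the weaker inhibitor of the pair, and the gap to compound 1 lies beyond the scatter. Compound 3 `CC(C)/C=C/C=C/C(=O)NC1=CC(O)(CCC(N)=O)C=CC1=O` keeps the core of compound 2 and changes only the end of the side chain: isopropyl in place of isobutyl on a double-bonded chain carbon bound to a double-bonded chain carbon. The change sits on a double-bonded chain carbon bound to a double-bonded chain carbon, and it turns 6-methylhepta-1,3-dien-1-yl into 5-methylhexa-1,3-dien-1-yl. For the measured compounds named here, no measured pair in this small series shows this change, so the direction stays open and no step beyond the scatter is expected in this assay. The expected change is a 1.1-fold higher number from compound 2 to compound 3 (0.04 log units; within the scatter). Compound 3 is estimated at 11 ug/mL, with an expected range of 4 ug/mL to 28 ug/mL.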

Compound 3, half-maximal inhibitory concentration: 10 ug/mL
Compound 3: the middle estimate sits 1.1-fold (0.04 log units) above what was measured; the measured number falls inside the stated range.
By their numbers in this assay, from the lowest: compound 1; then compounds 2 and 3 (each within the scatter of the next).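

In this assay, isopropyl in place of isobutyl on a double-bonded chain carbon bound to a double-bonded chain carbon gives a 1.0-fold higher number from compound 2 to compound 3 (0.00 log units; within the scatter), a step within the scatter. The earlier compounds shown here share one chain and say nothing about its end; this pair shows that, on the core of compound 2, going from 6-methylhepta-1,3-dien-1-yl to 5-methylhexa-1,3-dien-1-yl leaves the read-out flat. Nothing on hand explains this flat step.

On these data alone, whether a longer chain, or a chain end carrying an amine or a carboxylic acid, would move the number beyond the scatter stays open. Also open, as far as these compounds go, is whether isopropyl in place of isobutyl on the core of compound 1 would give the same flat result.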